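Swapping pentyl for 3-fluorophenyl on the core

The source may report more compounds than this note shows. Statements on the series, on what has been measured and on what is new or still open speak of the compounds shown alone.

Compound 3 `CCCCCc1cc(C(F)(F)F)ccc1CNC(=O)C(C)c1ccc(NS(C)(=O)=O)c(F)c1` gives the lowest number of the three in an assay on CHO cells for antagonist activity at transient receptor potential cation channel subfamily V member 1 (Homo sapiens), read by FLIPR (a lower number here means a stronger inhibitor, a higher number a weaker inhibitor), at 0.4 nM. Compound 2 `CC1CCN(c2cc(C(F)(F)F)ccc2CNC(=O)C(C)c2ccc(NS(C)(=O)=O)c(F)c2)CC1` gives 0.9 nM and compound 1 `CC(C(=O)NCc1ccc(C(F)(F)F)cc1N1CCCCCCC1)c1ccc(NS(C)(=O)=O)c(F)c1` gives 2.8 nM. Compound 4 `CC(C(=O)NCc1ccc(C(F)(F)F)cc1-c1cccc(F)c1)c1ccc(NS(C)(=O)=O)c(F)c1` differs from compound 3 by 3-fluorophenyl in place of pentyl on an aromatic carbon. Among the compounds with values here, the steps that bear on this position are a 2.3-fold lower number from compound 2 to compound 3 (0.35 log units; beyond the scatter) and a 7.0-fold lower number from compound 1 to compound 3 (0.85 log units; beyond the scatter), both modest, together with a 3.1-fold lower number from compound 1 to compound 2 (0.49 log units; beyond the scatter). Every change made at this position moved the number beyond the scatter, and because compound 3 gives 0.4 nM, the lowest number here, a further change is expected to raise it, a modest step of a 3.0-fold higher number from compound 3 to compound 4 (0.48 log units; beyond the scatter). Compound 4 is therefore estimated at 1.2 nM in this assay, with a range from 0.3 nM to 5 nM.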

Compound 4, inhibition constant: 1.9 nM
Compound 4: the middle estimate sits 1.6-fold (0.20 log units) below what was measured, within the range that was stated.
By their numbers in this assay, from the lowest: compound 3; then compound 2; then compounds 4 and 1 (each within the scatter of the next).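

An aromatic ring at this position, on an aromatic carbon, did not match the open-chain pentyl in this assay, with a 4.8-fold higher number from compound 3 to compound 4 (0.68 log units; beyond the scatter) as the step. It also fell short of 4-methylpiperidin-1-yl, with a 2.1-fold higher number from compound 2 to compound 4 (0.32 log units; beyond the scatter) as the step, while the eight-membered ring of compound 1 could not be told apart from 3-fluorophenyl, with a 1.5-fold lower number from compound 1 to compound 4 (0.17 log units; within the scatter) as the step. Nothing given here explains these steps. The compounds shown leave open how a plain phenyl, a longer chain or a morpholine would read at this position.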